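This account rests on a few compounds, and the source may have more. Where it says the series, first, only, none or still open, it means among the compounds named here.

Working notes on the series. The shared core is carried by compound 1 `CCOC(=O)CCCCCOc1cccc(CN(C(=O)c2ccc(-c3cnc(OC)nc3OC)cc2)C(C)C)c1` and compound 2 `CCOC(=O)CCCCCOc1cccc(CN(C(=O)c2ccc(-c3cc(OC)cc(OC)c3)cc2)C(C)C)c1`, which differ only at the terminal aromatic group. In an ADME assay on Raji cells (Homo sapiens) for cytotoxicity, read by CellTiter-Glo and resazurin assay, with a stated time of 72 h (on this read-out higher numbers stand for an effect only at larger amounts of compound and lower numbers for an effect already at smaller amounts), compound 1 gives > 26000 nM, a limit of the assay rather than a number. In this assay compound 2 likewise gives > 26000 nM, again a limit and not a number. The step that the two limits leave unreadable from compound 1 to compound 2 therefore cannot be sized, since both ends sit at the same limit (the limit of > 26000 nM in this assay, at which 2 of the 2 values shown sit). Compound 2 thus stands where every value shown stands: at the limit, with no numeric reading in this assay.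

The next compound, compound 3 `CCOC(=O)CCCCCOc1cccc(CN(C(=O)c2ccc(-c3cccc(CC(=O)O)c3)cc2)C(C)C)c1`, changes the same position once more: 3-(carboxymethyl)phenyl in place of 3,5-dimethoxyphenyl on an aromatic carbon. No measured step bears on this change, and the one step shown is unreadable. Among the measured compounds shown here, with no numeric anchor, the expectation is that compound 3 also returns a limit, so the step that the limit leaves unreadable from compound 2 to compound 3 is expected to be no more than a step not readable beyond the scatter. Compound 3 is accordingly estimated at 30000 nM, within 15000 nM to 60000 nM, most likely reported as a limit rather than a number.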

Compound 3, half-maximal effective concentration: > 26000 nM
Compound 3 was reported as a limit; the forecaster's own chance of this, stated with the estimate: 85%; the middle value does not contradict the limit.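

The steps among compound 1, compound 2 and compound 3 cannot be read in this assay, since all three compounds give a limit of the assay and not a number: the limit of > 26000 nM in this assay, at which 3 of the 3 values shown sit.

What stays open is whether any terminal aromatic group on the shared core gives a numeric reading in this assay, and how the three groups shown would then rank.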